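Amide variation in the series: compound 3 to compound 4

The source may report more compounds than this note shows. Statements on the series, on what has been measured and on what is new or still open speak of the compounds shown alone.

Measured compounds:
compound 1, `Cn1c(-c2ccccc2F)cnc1NC(=O)c1ccc(F)cc1`: a limit, > 100000 nM, in a toxicity assay on THP-1 cells (Homo sapiens) for inhibition; a higher number here means that more compound is tolerated, a lower number that less compound is tolerated
compound 2, `Cn1c(-c2cccc(F)c2)cnc1NC(=O)c1ccc(F)cc1`: 58000 nM in this assay
compound 3, `COc1ccc(-c2cnc(NC(=O)CCc3ccccc3)n2C)cc1`: a limit, > 100000 nM, in this assay

Compound 3 stands at the limit of this assay with > 100000 nM, which is the limit of > 100000 nM in this assay, at which 2 of the 3 values shown sit. Within the data shown here, compound 2 is the only compound of the three with a number rather than a limit, giving 58000 nM in this assay.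

Among the measured compounds shown here, the one measured step, an at least 1.7-fold lower number from compound 1 to compound 2 (0.23 log units; that floor lies within the scatter), changes the aryl on the shared core and leaves the amide side untouched, so it does not bear directly on the change considered here. For the measured compounds named here, no measured pair varies the group on the carbonyl carbon alone.

Compound 4 is `COc1ccc(-c2cnc(NC(=O)c3cccc(F)c3)n2C)cc1`. It differs from compound 3 by 3-fluorophenyl in place of phenethyl on a carbonyl carbon.

Going by the values given here, with the only pair of numbers being a step that starts at a limit and ends at a number that is itself within the scatter of that limit, no direction can be read from the data for the change on the carbonyl carbon. Compound 4 is therefore expected to remain near the limit of this assay, and its estimate is 90000 nM with a range from 40000 nM to 200000 nM. The expected step is an at least 1.1-fold lower number from compound 3 to compound 4 (0.04 log units; that floor lies within the scatter), not beyond the scatter.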

Compound 4, half-maximal cytotoxic concentration: > 100000 nM
Compound 4 was reported as a limit (the forecaster's own chance of this, stated with the estimate: 50%); middle value at least 1.1-fold (0.04 log units) away from the limit.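

Compound 3 and compound 4 are both reported as limits in this assay, so the change from phenethyl to 3-fluorophenyl on a carbonyl carbon gives no readable step: the limit of > 100000 nM in this assay, at which 3 of the 4 values shown sit.

The compounds shown leave open what concentration of compound 3 or compound 4 is actually tolerated, and whether this change on the carbonyl carbon alters the read-out at all.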